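The source may hold more compounds than are shown below. What is called first, only, known or untested is meant among the compounds shown, and "the series" means these compounds.

Working notes on the series, tested in an ADME assay on MDCK cells (Canis lupus familiaris) for cytotoxicity; on this read-out higher numbers stand for lower toxicity in this test and lower numbers for higher toxicity in this test.

Compound 1 `O=[N+]([O-])C1=CNc2nc(C(F)(F)F)nn2C1c1c(O)cc(O)cc1O` gives 838000 nM in this assay. Compound 2 `O=[N+]([O-])C1=CNc2ncnn2C1O` gives 123000 nM in this assay. For compound 3 `O=[N+]([O-])C1=CNc2ncnn2C1c1c(O)cc(O)cc1O` the read-out is a limit of this assay, > 1030000 nM, not a number; that sits at the limit of > 1030000 nM in this assay, at which 1 of the 3 values shown sits. Compound 1 and compound 3 differ in one place: trifluoromethyl in place of hydrogen on an aromatic carbon. The step of an at least 1.2-fold lower number from compound 3 to compound 1 (0.08 log units; that floor lies within the scatter) is recorded as an at least 1.2-fold lower number from compound 3 to compound 1 (0.08 log units; that floor lies within the scatter). Of the two numbers shown, compound 2 stands lowest, with compound 1 the nearest.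

Compound 4 `O=[N+]([O-])C1=CNc2nc(C(F)(F)F)nn2C1O` is not yet measured. It differs from compound 2 by trifluoromethyl in place of hydrogen on an aromatic carbon, the same kind of change as from compound 3 to compound 1; the two place lines read the same word for word. How the core of compound 2 differs from the core of compound 3 is not broken down here.

For compound 4 the expected step is a 1.2-fold lower number from compound 2 to compound 4 (0.09 log units; within the scatter), beside the earlier one, because the measured step of an at least 1.2-fold lower number from compound 3 to compound 1 (0.08 log units; that floor lies within the scatter) sits within the scatter, so the number is expected close to that of compound 2. Compound 4 is therefore estimated at 100000 nM, expected to fall between 40000 nM and 300000 nM.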

Compound 4, half-maximal cytotoxic concentration: 33000 nM
Compound 4: middle estimate off by 3.0-fold (0.48 log units), on the high side, outside the stated range (below it).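

In this assay, trifluoromethyl in place of hydrogen on an aromatic carbon gives a 3.7-fold lower number from compound 2 to compound 4 (0.57 log units; beyond the scatter), and set beside the earlier step on the other core, the comparison reads: the same change on two cores in this assay, an at least 1.2-fold lower number (0.08 log units; that floor lies within the scatter) from compound 3 to compound 1 and a 3.7-fold lower number (0.57 log units; beyond the scatter) from compound 2 to compound 4; the limit leaves it open whether they differ. Going by these compounds, compound 3 stands at a limit of the assay and not at a number, > 1030000 nM, so the step on its core has only a floor and its true size remains unknown. The series therefore shows a measured lowering on the core of compound 2, but it neither shows that the size of this step carries over to the core of compound 3 nor shows that it does not.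

The compounds shown leave open whether another group on the same aromatic carbon, such as methyl, an amine or a nitrile, would lower the number as trifluoromethyl does on the core of compound 2. They also leave open how trifluoromethyl would behave on any core other than these two.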